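From 3-nitrophenyl to 3-iodophenyl in a flat series

The source may report more compounds than this note shows. Statements on the series, on what has been measured and on what is new or still open speak of the compounds shown alone.

Of the compounds shown here, three on the shared core have been read in a functional assay on HeLa cells (Homo sapiens) for antiproliferative activity, read by MTT assay, with a stated time of 48 h; a higher number here means a weaker inhibitor, a lower number a stronger inhibitor: compound 1 (`COc1ccc2nc(NC(c3cn(-c4ccccc4)nc3-c3ccc(Cl)cc3)c3c(O)ccc4ccccc34)sc2c1`) gives 5200 nM, compound 2 (`COc1ccc2nc(NC(c3cn(-c4ccccc4)nc3-c3ccc(F)cc3)c3c(O)ccc4ccccc34)sc2c1`) gives 4630 nM, and compound 3 (`COc1ccc2nc(NC(c3cn(-c4ccccc4)nc3-c3cccc([N+](=O)[O-])c3)c3c(O)ccc4ccccc34)sc2c1`) gives 6140 nM. Compound 3 sits level with the other two, as a 1.2-fold higher number from compound 1 to compound 3 (0.07 log units; within the scatter) and a 1.3-fold higher number from compound 2 to compound 3 (0.12 log units; within the scatter) both lie within the scatter.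

The next structure is compound 4 (`COc1ccc2nc(NC(c3cn(-c4ccccc4)nc3-c3cccc(I)c3)c3c(O)ccc4ccccc34)sc2c1`), with iodo in place of nitro on an aromatic carbon, meta to a large group: iodo in place of nitro on an aromatic carbon. Among the measured compounds shown here, no iodo compound has been measured, so the evidence is indirect. The closest guidance comes from the exchanges already made on this same aryl group. Those are the two steps above and the halogen exchange, a 1.1-fold lower number from compound 1 to compound 2 (0.05 log units; within the scatter), and all three stay within the scatter. On that basis, no step beyond the scatter is expected in this assay, and no direction can be favoured. For the measured compounds named here, the expected step is a 1.2-fold lower number from compound 3 to compound 4 (0.06 log units; within the scatter), which remains an estimate resting on only three measured compounds. The estimated value for compound 4 is 5300 nM, with an expected range of 2800 nM to 10000 nM.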

Compound 4, half-maximal inhibitory concentration: 6240 nM
Beside the measured number, compound 4's estimate is 1.2-fold (0.07 log units) below it; the range from low to high includes it.
By their numbers in this assay, from the lowest: compounds 2, 1, 3 and 4 (each within the scatter of the next).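

In this assay, the swap at this position, on an aromatic carbon meta to a large group, removes nitro with its hydrogen-bond acceptors and its double bond outside the ring and puts in iodo, which has neither, yet the read-out stays level, with a 1.0-fold higher number from compound 3 to compound 4 (0.01 log units; within the scatter) as the printed step. The 3-iodophenyl group also reads level with the two 4-halophenyl groups, with a 1.2-fold higher number from compound 1 to compound 4 (0.08 log units; within the scatter) on the chloro side and a 1.3-fold higher number from compound 2 to compound 4 (0.13 log units; within the scatter) on the fluoro side, so among these four compounds every exchange on this aryl group stays within the scatter and none goes against that flat pattern. No data are available that would account for this flatness.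

Going by these compounds, whether an amine, a carboxylic acid or a longer chain on this aryl group would give a step beyond the scatter remains open. Also open, on these data alone, is whether the same flat reading would hold for changes elsewhere on the shared core, or outside this assay, since these four compounds speak only to this one aryl group in this one assay.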